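The source may hold more compounds than are shown below. What is called first, only, known or untested is meant among the compounds shown, and "the series" means these compounds.

Working notes on the series. Three compounds have numbers in a functional assay on the whole organism (strain CF-1) for inhibition, with Mus musculus as the target; on this read-out lower numbers stand for an effect already at smaller amounts and higher numbers for an effect only at larger amounts of compound. Compound 1 `CN(C)CCn1nc(CN(C)C)n(-c2ccc(Cl)cc2C(=O)c2ccccc2)c1=O` gives 18 mg/kg in this assay. Compound 2 `Cc1nnc(CN2CCCC2)n1-c1ccc(Cl)cc1C(=O)c1ccccc1` gives 2 mg/kg. Compound 3 `CN(C)Cc1nnc(C2CC2)n1-c1ccc(Cl)cc1C(=O)c1ccccc1Cl` gives 1 mg/kg, the lowest number of the three; its nearest neighbour is compound 2, whose number lies within the scatter, and its furthest is compound 1, whose number lies beyond the scatter. Among the measured compounds shown here, no two of the measured compounds differ in only one place, so no single step between measured compounds can be read off.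

Compound 4 `Cc1nnc(CN(C)C)n1-c1ccc(Cl)cc1C(=O)c1ccccc1Cl` has not yet been measured. It differs from compound 3 by a single change: methyl in place of cyclopropyl on an aromatic carbon. Compound 2 also carries a methyl on an aromatic carbon of a five-membered aromatic ring with 3 nitrogen, and its number sits within the scatter of compound 3, though compound 2 differs from compound 3 in other places as well, so this is only a loose pointer.

For the measured compounds named here, with no measured step for this change, the expectation for this assay is a step from compound 3 to compound 4 of a 1.5-fold higher number from compound 3 to compound 4 (0.18 log units; within the scatter), which is estimated to stay within the usual scatter and with no clear direction. Compound 4 is therefore expected to give about 1.5 mg/kg in this assay, with an estimated range from 0.5 mg/kg to 5 mg/kg.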

Compound 4, dose for half-maximal effect: 0.28 mg/kg
The estimate for compound 4 lay 5.4-fold (0.73 log units) above the measured number; measured number below the stated range.
By their numbers in this assay, from the lowest: compound 4; then compounds 3 and 2 (each within the scatter of the next); then compound 1.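

Among the compounds shown here, this is the first single change that can be read: at the aromatic carbon between two ring nitrogen atoms, methyl in place of cyclopropyl gives a 3.6-fold lower number from compound 3 to compound 4 (0.55 log units; beyond the scatter) in this assay, a modest step beyond the scatter. The position is therefore not indifferent to its group, a point compounds 1 to 3 could not settle, since none of them differs from another in only one place. The cyclopropyl ring is also not needed for a low number here: the lower number comes with 1 heavy atom in place of 3 and no ring, while the counts of hydrogen-bond donors and acceptors and the net charge stay the same. No measured evidence bears on why this step occurs.

With only two groups compared at this position, the compounds shown do not tell whether the trend would continue to hydrogen or extend to ethyl, a longer chain or an amine. They also leave open whether the step holds when the (dimethylamino)methyl group is replaced.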